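A few compounds are considered here, and "the series" means these few. Any claim that something is new, unique, unknown or untested is made for them only; others in the source may bear on it.

Compound 1, `CCN(CC)C(=O)c1ccc(-c2cc(-c3cc(OC)ccc3OC)no2)s1`: in a functional assay on A549 cells (Homo sapiens) for cytotoxicity, read by XTT assay, with a stated time of 72 h (on this read-out lower numbers stand for stronger inhibition and higher numbers for weaker inhibition), compound 1 gives 11000 nM.
Compound 2, `CN(Cc1ccccc1)C(=O)c1ccc(-c2cc(C3=CC(=O)C=CC3=O)no2)s1`: in this assay compound 2 gives > 30000 nM, a limit of the assay.
Compound 3, `COc1ccc(OC)c(-c2cc(-c3ccc(C(=O)N(C)C)s3)on2)c1`: in this assay compound 3 gives > 30000 nM, again only a limit of the assay.

Compound 3 thus stands at the edge of what this assay reports, sharing that edge with compound 2 (the limit of > 30000 nM in this assay, at which 2 of the 3 values shown sit); only compound 1 has a number. Compound 4, `COc1ccc(OC)c(-c2cc(-c3ccc(C(=O)N(C)Cc4ccccc4)s3)on2)c1`, differs from compound 3 by phenyl in place of hydrogen on a saturated chain carbon bound to an amide-type nitrogen. Among the compounds with values here, one measured step touches the same amide: an at least 2.7-fold higher number from compound 1 to compound 3 (0.43 log units; beyond the scatter). Compound 2, which carries the benzyl(methyl)amino group on a different ring, also sits at the limit. Compound 3 gives only a limit, so the step of an at least 1.2-fold lower number from compound 3 to compound 4 (0.07 log units; that floor lies within the scatter) is expected to be small or unresolved. Compound 4 is therefore estimated at 25000 nM, within 8000 nM to 60000 nM, with a fair chance of another limit.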

Compound 4, half-maximal inhibitory concentration: > 30000 nM
Compound 4: no number, only a limit (the forecaster's own chance of this, stated with the estimate: 55%); at least 1.2-fold (0.07 log units) between middle value and limit.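

In this assay, benzyl(methyl)amino in place of diethylamino on the carbonyl carbon gives an at least 2.7-fold higher number from compound 1 to compound 4 (0.43 log units; beyond the scatter) and shows that a second replacement of diethylamino on this amide also ends without a number. The steps from compound 3 and compound 2 to compound 4 cannot be read, so phenyl on the saturated chain carbon shows no measurable change. Compound 4 gives only a limit, the same one as compound 3 and compound 2: the limit of > 30000 nM in this assay, at which 3 of the 4 values shown sit.

From the compounds shown here alone, whether dipropylamino or piperidine on the carbonyl carbon would give a number remains open. Going by these compounds, how far compound 2, compound 3 and compound 4 lie beyond the limit also remains open.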